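Propargylamine hydroxamates: chain length step from compound 2

The source may report more compounds than this note shows. Statements on the series, on what has been measured and on what is new or still open speak of the compounds shown alone.

Measured in an assay on GL26 cells for inhibition of Amine oxidase [flavin-containing] A (Homo sapiens), read by scintillation counting, with a stated time of 20 min; on this read-out higher numbers stand for weaker inhibition and lower numbers for stronger inhibition:
- compound 1 `C#CCN(C)CCCOc1cc(NCc2ccc(/C=C/C(=O)NO)cc2)ccc1Cl`: 4 nM
- compound 2 `C#CCN(C)CCCOc1cc(NC(=O)CCCCCCCC(=O)NO)ccc1Cl`: 20 nM
- compound 3 `C#CCN(C)CCCOc1ccc(NC(=O)CCCCCCC(=O)NO)cc1Cl`: 30 nM

Compound 2 stands second highest of the three numbers. Its nearest neighbour is compound 3, whose value in this assay is within the scatter of compound 2, so no order between these two can be read. Compound 1 lies furthest away, with a lower number that is beyond the scatter; that pair is the only gap in the set that counts as a real difference.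

Compound 4 `C#CCN(C)CCCOc1cc(NC(=O)CCCCCCC(=O)NO)ccc1Cl` is not yet measured. It differs from compound 2 in one place: hydroxycarbamoyl in place of (hydroxycarbamoyl)methyl on a saturated chain carbon, six bonds along the chain from a carbonyl carbon. Within the data shown here, no step between two measured compounds isolates this kind of change, so nothing sets its size. The three numbers shown span only a narrow band, and compound 3, which shares the shorter chain of compound 4 on a differently substituted core, sits within the scatter of compound 2. The expected step from compound 2 to compound 4 in this assay is therefore a 1.4-fold higher number from compound 2 to compound 4 (0.15 log units; within the scatter), not beyond the scatter in either direction. Compound 4 is estimated at 28 nM, within the range 11 nM to 75 nM.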

Compound 4, half-maximal inhibitory concentration: 3250 nM
Compound 4: middle estimate off by 120-fold (2.06 log units), on the low side; measured number outside the range, above it.
By their numbers in this assay, from the lowest: compound 1; then compounds 2 and 3 (each within the scatter of the next); then compound 4.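

In this assay this series gives its first step that isolates a single change: hydroxycarbamoyl in place of (hydroxycarbamoyl)methyl on a saturated chain carbon, six bonds along the chain from a carbonyl carbon, gives a 160-fold higher number from compound 2 to compound 4 (2.21 log units; beyond the scatter) and the step is large. The chain position is therefore far from indifferent on the shared core, since this small shortening separates a compound near the earlier band from one well outside it. Nothing available bears on why the step is this large.

From the compounds shown here alone, whether a longer chain than that of compound 2 keeps the inhibition, and whether a carboxylic acid or an amine at the chain end does so, stays open. Going by these compounds, with one pair, it also stays open whether a step of this size holds on the core of compound 1.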